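Removing the Methyl From the Benzylamide of Compound 1

This account rests on a few compounds, and the source may have more. Where it says the series, first, only, none or still open, it means among the compounds named here.

Compound 1 `C=CC1=C(C(=O)NCc2ccc(C)cc2)C(c2ccc(OC)c(OC)c2)OC1` was tested in a functional assay on SW480 cells (Homo sapiens) for cytotoxicity, read by MTT assay, with a stated time of 24 h (on this read-out higher numbers stand for weaker inhibition and lower numbers for stronger inhibition), where it reached only the limit of the assay, > 100000 nM, so no number is known for it. Compound 3 `C=CC1=C(C(=O)NCc2ccccc2)C(c2ccc(F)cc2)OC1` likewise sits at a limit in this assay, > 100000 nM. Only compound 2 `C=CC1=C(C(=O)NCc2ccc(OC)c(OC)c2)C(c2ccc(OC)cc2)OC1` returns a measured value in this assay, 13500 nM. Thus the limit of > 100000 nM in this assay, at which 2 of the 3 values shown sit, describes where compound 1 stands: at a limit shared with compound 3, while compound 2 is the one compound that gives a number.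

Compound 4 `C=CC1=C(C(=O)NCc2ccccc2)C(c2ccc(OC)c(OC)c2)OC1` differs from compound 1 by hydrogen in place of methyl on an aromatic carbon. Among the compounds with values here, no step between two measured compounds covers this change; compound 3 carries the benzyl group but a different aryl group on the shared core, so its two values with compound 1 show only that both lie at the limit. On these data alone, with both neighbours at the limit, the direction of the step is unknown, and a step of no size beyond the scatter is expected, so that a number no higher from compound 1 to compound 4 (the limit leaves the size open) is estimated to leave compound 4 at the same limit. Compound 4 is therefore estimated at 100000 nM, within a range from 30000 nM to 300000 nM, with a strong chance that this assay again reports only a limit.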

Compound 4, half-maximal inhibitory concentration: > 100000 nM
Compound 4 was reported as a limit; the forecaster's own chance of this, stated with the estimate: 75%; the middle value lies on the limit itself.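

In this assay compound 4 gives only a limit, as compound 1 does, so no step can be read between compound 1 and compound 4: the limit of > 100000 nM in this assay, at which 3 of the 4 values shown sit. The compounds shown leave open whether hydrogen in place of methyl on this aromatic carbon changes the cytotoxicity in this assay at all.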